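Sulfonamide nitrogen substitution on the alkynyl phenoxyacetic acid series

The source may report more compounds than this note shows. Statements on the series, on what has been measured and on what is new or still open speak of the compounds shown alone.

Of the compounds shown here, two have been measured in an assay on CHO cells for displacement of a labelled ligand from prostaglandin D2 receptor 2 (Homo sapiens), read by scintillation counting; a lower number here means a stronger inhibitor, a higher number a weaker inhibitor. Compound 1 `Cc1ccc(S(=O)(=O)N2CCN(C)CC2)cc1C#Cc1cc(Cl)ccc1OCC(=O)O` gives 21 nM. Among the compounds with values here, compound 2 `CNS(=O)(=O)c1ccc(C)c(C#Cc2cc(Cl)ccc2OCC(=O)O)c1` gives 10 nM, the lower of the two numbers; the change a 2.1-fold lower number from compound 1 to compound 2 (0.32 log units; beyond the scatter) is the only measured step so far.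

Compound 3 `Cc1ccc(S(=O)(=O)N(C)CCN(C)C)cc1C#Cc1cc(Cl)ccc1OCC(=O)O` has not yet been measured. It differs from compound 2 by 2-(dimethylamino)ethyl in place of hydrogen on a sulfonamide nitrogen. Within the data shown here, the one measured step bears on this only loosely: it swaps the whole sulfonamide substituent rather than adding a chain on the nitrogen, and it was modest. Compound 1 carries a basic nitrogen on its sulfonyl substituent and sits at the higher number, so a drift back toward that number is plausible for compound 3, though nothing here forces it.

For compound 3 a step of about a 1.5-fold higher number from compound 2 to compound 3 (0.18 log units; within the scatter) is expected, within or just beyond the scatter. Compound 3 is therefore estimated at 15 nM, with a likely range from 6 nM to 40 nM.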

Compound 3, inhibition constant: 369 nM
The estimate for compound 3 lay 25-fold (1.39 log units) below the measured number; the measured number lies above the stated range.
By their numbers in this assay, from the lowest: compound 2; then compound 1; then compound 3.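

In this assay, within the data shown here, the sulfonamide nitrogen proves far less forgiving than the earlier compounds suggested: 2-(dimethylamino)ethyl in place of hydrogen gives a 37-fold higher number from compound 2 to compound 3 (1.57 log units; beyond the scatter), a change much larger than the earlier 2.1-fold lower number from compound 1 to compound 2 (0.32 log units; beyond the scatter). The comparison with the ring-bearing sulfonamide gives an 18-fold higher number from compound 1 to compound 3 (1.24 log units; beyond the scatter), so (2-(dimethylamino)ethyl)(methyl)amino is no stand-in for 4-methylpiperazin-1-yl, even though both groups carry a further amine nitrogen and neither leaves a hydrogen on the sulfonamide nitrogen. No measurement bearing on the reason for this large step is available.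

On these data alone, it remains open whether the step follows the terminal dimethylamino group or the chain itself. A 2-methoxyethyl chain on the same nitrogen, or a 3-(dimethylamino)propyl chain, would help separate those two readings.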